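The source may hold more compounds than are shown below. What is called first, only, known or untested is meant among the compounds shown, and "the series" means these compounds.

Of the compounds shown here, three have so far been measured in a functional assay on NCI/ADR-RES cells (Homo sapiens) for inhibition, read by sulforhodamine B assay, with a stated time of 48 h; on this read-out higher numbers stand for weaker inhibition of growth and lower numbers for stronger inhibition of growth. Compound 1 `COc1cc(C)cc(-c2c(-c3ccnc(-c4ccc(C(C)=O)cc4)c3)cnn2CC#N)c1` gives 2870 nM, compound 2 `COc1cc(C)cc(-c2nn(CC#N)cc2-c2ccc(-c3cccc(C(C)=O)c3)nc2)c1` gives 1310 nM, and compound 3 `Cc1cc(O)cc(-c2nn(CC#N)cc2-c2ccnc(-c3ccc(Oc4ccccc4)cc3)c2)c1` gives 2060 nM. Compound 3 stands second highest of the three numbers; its nearest is compound 1 and its furthest is compound 2, and both of those gaps lie within the scatter, so the three cannot be ranked against one another. Compound 4 `Cc1cc(O)cc(-c2nn(CC#N)cc2-c2ccnc(-c3ccc(N(C)C)cc3)c2)c1` differs from compound 3 by dimethylamino in place of phenoxy on an aromatic carbon. Among the measured compounds shown here, no measured pair shows this change, so the step expected in this assay is a 1.0-fold lower number from compound 3 to compound 4 (0.01 log units; within the scatter), which amounts to none beyond the scatter. On that basis compound 4 is estimated at 2000 nM, with a range from 700 nM to 6000 nM.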

Compound 4, concentration for 50% growth inhibition: 2540 nM
For compound 4 the middle estimate is 1.3-fold (0.10 log units) below the measured one; the range from low to high includes it.
By their numbers in this assay, from the lowest: compounds 2, 3, 4 and 1 (each within the scatter of the next, the first and the last beyond it).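

In this assay, dimethylamino in place of phenoxy on an aromatic carbon, para to a large group, gives a 1.2-fold higher number from compound 3 to compound 4 (0.09 log units; within the scatter). This first comparison of compounds differing in one place shows that, at this position, going from 7 heavy atoms with a six-membered aromatic ring to 3 heavy atoms with no ring leaves the number within the scatter. No evidence bears on this result. The compounds shown leave open whether a carboxylic acid or a primary amine on this carbon would move the number beyond the scatter.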